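The source may hold more compounds than are shown below. What is called first, only, known or untested is meant among the compounds shown, and "the series" means these compounds.

Compound 1 `O=C(Nc1ccccc1)Nc1cccc(CNc2nccnc2Cl)c1` gives 19800 nM in a functional assay on T-24 cells (Homo sapiens) for antiproliferative activity, read by MTT assay, with a stated time of 48 h; a higher number here means a weaker inhibitor, a lower number a stronger inhibitor.
Compound 2 `CN(C)c1ccc(NC(=O)Nc2cccc(CNc3nccnc3Cl)c2)cc1` gives 20200 nM in this assay.
Compound 3 `Cc1ccc(NC(=O)Nc2cccc(CNc3nccnc3Cl)c2)c(C)c1` gives 9230 nM in this assay.

Compound 2 has the highest number of the three, though compound 1 sits within the scatter of it, as a 1.0-fold higher number from compound 1 to compound 2 (0.01 log units; within the scatter) shows. Compound 4 `O=C(Nc1cccc(CNc2nccnc2Cl)c1)Nc1ccc(Cl)cc1Br` differs from compound 2 in one place: 2-bromo-4-chlorophenyl in place of 4-(dimethylamino)phenyl on an amide-type nitrogen. Within the data shown here, the one comparable step, swapping the group on the amide-type nitrogen, gave a 2.2-fold lower number from compound 2 to compound 3 (0.34 log units; beyond the scatter), a modest lowering. On that basis a modest lowering is expected for compound 4 as well, of about a 2.0-fold lower number from compound 2 to compound 4 (0.31 log units; beyond the scatter). Compound 4 is therefore estimated at 10000 nM, with a range of 4000 nM to 25000 nM.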

Compound 4, half-maximal inhibitory concentration: 6650 nM
Beside the measured number, compound 4's estimate is 1.5-fold (0.18 log units) above it; low and high end bracket the measured number.
By their numbers in this assay, from the lowest: compounds 4 and 3 (each within the scatter of the next); then compounds 1 and 2 (each within the scatter of the next).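

Placing 2-bromo-4-chlorophenyl on the amide-type nitrogen puts compound 4 within the scatter of the 2,4-dimethylphenyl ring (a 1.4-fold lower number from compound 3 to compound 4 (0.14 log units; within the scatter)). Its steps from the other two rings are larger (a 3.0-fold lower number from compound 2 to compound 4 (0.48 log units; beyond the scatter); a 3.0-fold lower number from compound 1 to compound 4 (0.47 log units; beyond the scatter)), so a ring bearing chlorine and bromine reaches the same low range as one bearing two methyl groups in this assay. Nothing measured here accounts for this lowering.

From the compounds shown here alone, it remains open whether the bromo or the chloro group alone would give the same number. A ring carrying a carboxylic acid or a nitrile is also untested among these compounds.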